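Second chloro on the chlorophenyl arm

The source may hold more compounds than are shown below. What is called first, only, known or untested is meant among the compounds shown, and "the series" means these compounds.

Compound 1 `C=CCn1c(=O)/c(=C\c2cccc(Cl)c2)[nH]c(=O)/c1=C\c1ccccc1OC` is the reference point of the pair measured so far. In a functional assay on NCI-H1975 cells (Homo sapiens) for cytotoxicity, read by CCK-8 assay, with a stated time of 72 h (a lower number here means a stronger inhibitor, a higher number a weaker inhibitor), compound 1 gives 5100 nM, the highest of the two numbers available. Compound 2 `C=CCn1c(=O)/c(=C\c2cccc(Cl)c2Cl)[nH]c(=O)/c1=C\c1ccccc1OC` carries a second chloro on the same ring; in this assay compound 2 gives 4500 nM, and the step of a 1.1-fold lower number from compound 1 to compound 2 (0.05 log units; within the scatter) sits within the scatter of repeated measurements.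

Compound 3 `C=CCn1c(=O)/c(=C\c2ccc(Cl)c(Cl)c2)[nH]c(=O)/c1=C\c1ccccc1OC` differs from compound 1 by chloro in place of hydrogen on an aromatic carbon. Among the measured compounds shown here, the only measured step that bears on this change is the one from compound 1 to compound 2, also a second chloro on the same ring, and that step was a 1.1-fold lower number from compound 1 to compound 2 (0.05 log units; within the scatter). With a single comparison of this kind, and that one within the scatter, no movement beyond the scatter is expected in this assay for the placement in compound 3 either. The expected step in this direction is a 1.2-fold lower number from compound 1 to compound 3 (0.07 log units; within the scatter). Compound 3 is therefore estimated to give about 4300 nM in this assay, with a range from 2000 nM to 9000 nM.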

Compound 3, half-maximal inhibitory concentration: "not active" (no number reported)
For compound 3 the study gives words and no number; the estimate stays without a comparison.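

Among the compounds shown here, for compound 3, this assay gives the words "not active" and no number, so no step from compound 1 or compound 2 to compound 3 can be read. Nothing shown accounts for this result. The compounds shown leave open how far the 3,4-dichlorophenyl arm of compound 3 separates it numerically from the 3-chlorophenyl arm of compound 1.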